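Thiazolidinone amide series: aryl changes on the ring nitrogen

A few compounds are considered here, and "the series" means these few. Any claim that something is new, unique, unknown or untested is made for them only; others in the source may bear on it.

Of the compounds shown here, three sharing one core have been measured. Compound 1 `COc1cccc(OC)c1N1C(=O)CSC1c1cccc(C(=O)NCCCCc2ccccc2)c1` carries a 2,6-dimethoxyphenyl on the amide-type nitrogen in the ring; in a functional assay on 143B cells (Homo sapiens) for inhibition, read by CCK-8 assay, with a stated time of 72 h, tested at 1 uM (a lower number here means less inhibition, a higher number more inhibition at the concentration tested (going by the name of the read-out)), compound 1 gives 31%. Compound 2 `COc1c(F)cccc1N1C(=O)CSC1c1cccc(C(=O)NCCCCc2ccccc2)c1` gives 5%, and compound 3 `CC(F)(F)c1cccc(N2C(=O)CSC2c2cccc(C(=O)NCCCCc3ccccc3)c2)c1` gives 1%. The step of a number 26 percentage points lower from compound 1 to compound 2 (beyond the scatter) and the step of a number 30 percentage points lower from compound 1 to compound 3 (beyond the scatter) are both beyond the scatter, while the step of a number 4 percentage points lower from compound 2 to compound 3 (within the scatter) is within it. Compound 3 therefore sits at the low end of the three numbers, indistinguishable from compound 2 and clearly below compound 1.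

Compound 4 `Cc1cccc(N2C(=O)CSC2c2cccc(C(=O)NCCCCc3ccccc3)c2)c1` differs from compound 3 in one place: methyl in place of 1,1-difluoroethyl on an aromatic carbon. For the measured compounds named here, none of the measured steps touches this substituent; all three exchange the whole aryl group on the ring nitrogen, so they show only that the dimethoxy pattern of compound 1 is the one that lifts the read-out, and that the two fluorinated aryls of compound 2 and compound 3 sit close together near the floor. Going by the values given here, with no step on the substituent itself, the expectation for compound 4 is a step of a number 5 percentage points higher from compound 3 to compound 4 (within the scatter), within the scatter. Compound 4 is estimated at 6%, with a range from -5% to 25%.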

Compound 4, a percentage reported as inhibition, at one concentration (the size of the read-out at that concentration, not a potency): 71%
Beside the measured number, compound 4's estimate is 65 percentage points below it; the whole stated range lies below it.
By their numbers in this assay, from the lowest: compounds 3 and 2 (each within the scatter of the next); then compound 1; then compound 4.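

In this assay, the exchange of methyl for 1,1-difluoroethyl on an aromatic carbon, meta to a large group, is a direct test of this substituent, and it gives a number 70 percentage points higher from compound 3 to compound 4 (beyond the scatter) as a large step. This single place therefore separates a read-out near the floor from the highest of the four numbers. The exchanges of the whole aryl group point the same way, with a number 66 percentage points higher from compound 2 to compound 4 (beyond the scatter) and a number 40 percentage points higher from compound 1 to compound 4 (beyond the scatter) both beyond the scatter, so the 2,6-dimethoxyphenyl of compound 1 does not give the highest read-out, and the simple 3-methylphenyl of compound 4 exceeds it. No measurement at hand bears on why this exchange has so large an effect.

Still open, as far as these compounds go, is how narrow the demand at this position is: whether ethyl, a single fluorine, methoxy or an amine keeps the read-out of compound 4 or drops it towards that of compound 3. Also open, from the compounds shown here alone, is whether a second methyl on the same aromatic ring adds to the read-out or takes it away, and how the read-out of compound 4 at a single concentration translates into a potency.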